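The source may hold more compounds than are shown below. What is called first, only, known or untested is meant among the compounds shown, and "the series" means these compounds.

Measured compounds:
Compound 1, `O=C(Nc1ccc2[nH]ncc2c1)c1ccc(Cl)c(Cl)c1`, in an assay on cells for inhibition of Amine oxidase [flavin-containing] B (Rattus norvegicus) (on this read-out lower numbers stand for stronger inhibition and higher numbers for weaker inhibition), gives 138 nM.
Compound 2, `O=C(Nc1ccc(Cl)c(F)c1)c1ccc2[nH]ncc2c1`, in this assay gives 2.61 nM.
Compound 3, `O=C(Nc1ccc(F)c(Cl)c1)c1ccc2cn[nH]c2c1`, in this assay gives 1070 nM.

Among these three, compound 3 stands at the highest number, the weakest inhibition of the set. Its nearest neighbour is compound 1, whose number lies well below it, a gap beyond the scatter; compound 2 stands far lower still, beyond the scatter by a wide margin. Compound 4, `O=C(Nc1ccc(O)c(Cl)c1)c1ccc2cn[nH]c2c1`, has not yet been measured. It differs from compound 3 in one place: hydroxy in place of fluoro on an aromatic carbon. Among the compounds with values here, no pair of measured compounds shows this change, so the data give no step to lean on. The expectation is a change of no more than modest size, if anything a slight rise in the number, and likely within the scatter. Compound 4 is therefore estimated at 1500 nM, with a range from 400 nM to 6000 nM, an expected step of a 1.4-fold higher number from compound 3 to compound 4 (0.15 log units; within the scatter).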

Compound 4, half-maximal inhibitory concentration: 3280 nM
Beside the measured number, compound 4's estimate is 2.2-fold (0.34 log units) below it; measured number inside the range.
By their numbers in this assay, from the lowest: compound 2; then compound 1; then compound 3; then compound 4.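

In this assay, within the data shown here, hydroxy in place of fluoro on an aromatic carbon gives a 3.1-fold higher number from compound 3 to compound 4 (0.49 log units; beyond the scatter), the first reading of any change at this position, which stands ortho to a chloro group and para to a large group. The swap brings in a hydrogen-bond donor and a hydrogen-bond acceptor, and on this shared core the number rises by a modest step, while inhibition remains measurable. Nothing among the data offers an explanation for this step.

The compounds shown leave open how an amine or a methoxy group at this position would compare with fluoro and hydroxy. They also leave open whether hydroxy in place of fluoro would bring a step of similar size on the core of compound 2.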